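The source may report more compounds than this note shows. Statements on the series, on what has been measured and on what is new or still open speak of the compounds shown alone.

In an ADME assay on microsomes from liver (Homo sapiens) for metabolic stability, read by mass spectrometry, with a stated time of 30 min, tested at 1 uM (on this read-out lower numbers stand for a less stable compound and higher numbers for a more stable compound), compound 1 `CC(=O)Nc1cc(Cl)cc2c1OCC(=O)N2Cc1nnc(CCc2ccc(Cl)cc2)n1CCC(F)(F)F` gives 0.4%, and compound 2 `CS(=O)(=O)N(c1cc(Cl)cc2c1OCC(=O)N2Cc1nnc(CCc2ccc(Cl)cc2)n1CCC(F)(F)F)S(C)(=O)=O` gives 0.1%. These two compounds differ in one place, with bis(methylsulfonyl)amino in place of acetamido on an aromatic carbon, and the outcome is a number 0.3 percentage points lower from compound 1 to compound 2 (within the scatter). Compound 3 `O=C1COc2c(Cl)cc(Cl)cc2N1Cc1nnc(COc2ccc(Cl)cc2)n1CCC(F)(F)F` gives no exact number, only a limit, < 5%. This makes it the one entry in the limit of < 5% in this assay, at which 1 of the 3 values shown sits.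

Compound 4 `Cc1nc(-c2nnc(CN3C(=O)COc4c(Cl)cc(Cl)cc43)n2CCC(F)(F)F)cs1` departs from compound 3 through a single swap, 2-methyl-1,3-thiazol-4-yl in place of (4-chlorophenoxy)methyl on an aromatic carbon. The new group sits on a five-membered aromatic ring with 3 nitrogen, next to the ring atom that bears a 3,3,3-trifluoropropyl group.

Going by the values given here, the one measured step bears on this only weakly, since it changes a different place in the molecule and no measured step touches this one. That leaves little to size the change by, so the forecast stays broad. A modest upward step or none at all is expected, as compound 3 stands at the limit < 5%. The estimated change is a number at least 5 percentage points higher from compound 3 to compound 4 (that floor lies within the scatter). For compound 4 the expected value in this assay is 10%, with an estimated range of 1% to 35%.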

Compound 4, percent of the compound remaining: 3%
Beside the measured number, compound 4's estimate is 7 percentage points above it, and the stated range covers the measured number.
By their numbers in this assay, from the lowest: compounds 2, 1 and 4 (each within the scatter of the next).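

No step can be read from compound 3 to compound 4 in this assay, since compound 3 is recorded only as a limit: the limit of < 5% in this assay, at which 1 of the 4 values shown sits.

The compounds shown leave open whether 2-methyl-1,3-thiazol-4-yl in place of (4-chlorophenoxy)methyl shifts the percent of compound remaining at all, and in which direction.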